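Amino for Trifluoromethyl: Expected Cytotoxicity of Compound 4

The compounds below may be only part of what the source reports. "The series", "measured", "known", "first", "only" and "open" are said of these compounds alone.

Three measured compounds and one still to be measured share a common core. Compound 1 `CC(C)Cc1nn(-c2nccs2)cc1C(=O)NCc1ccc(C(F)(F)F)cc1` was tested in a toxicity assay on HepG2 2.2.15 cells (Homo sapiens) for cytotoxicity, read by CCK-8 assay, with a stated time of 8 days; on this read-out lower numbers stand for higher toxicity in this test and higher numbers for lower toxicity in this test. In this assay compound 1 gives > 100000 nM, which is a limit of the assay and not a number. Compound 2 `CCOC(=O)c1cn(-c2ccccc2F)nc1CC(C)C` differs from it in several places. In this assay compound 2 likewise reaches only a limit, > 100000 nM. Going by the values given here, compound 3 `CC(C)Cc1nn(-c2cccc(F)c2)cc1C(=O)NNc1ccc(F)cc1` is the one compound with a resolved number: in this assay compound 3 gives 45400 nM. Among the compounds with values here, compound 1 therefore stands at the limit of > 100000 nM in this assay, at which 2 of the 3 values shown sit, and no two measured compounds differ in a single place, so no measured step is available.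

Compound 4 `CC(C)Cc1nn(-c2nccs2)cc1C(=O)NCc1ccc(N)cc1` differs from compound 1 in one place: amino in place of trifluoromethyl on an aromatic carbon; that is, amino in place of trifluoromethyl on an aromatic carbon, para to a large group. Within the data shown here, because compound 1 sits at the limit of > 100000 nM in this assay, at which 2 of the 3 values shown sit, there is no measured step to carry over, and no direction of change in this assay can be read from the values shown. The expectation is no step beyond the usual scatter, with a number no higher from compound 1 to compound 4 (the limit leaves the size open) as the expected size. Compound 4 is accordingly estimated at 100000 nM, within a range from 40000 nM to 300000 nM, and most likely reported again as a limit.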

Compound 4, half-maximal cytotoxic concentration: > 100000 nM
Compound 4 ended at the assay's limit; the forecaster's own chance of this, stated with the estimate: 75%; the middle value sits exactly at the limit.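

In this assay compound 4 gives > 100000 nM as a limit of the assay and not a number. Compound 1 also sits at a limit, so no step can be read between compound 1 and compound 4: the limit of > 100000 nM in this assay, at which 3 of the 4 values shown sit.
The compounds shown leave open whether amino in place of trifluoromethyl on an aromatic carbon changes the cytotoxic concentration in either direction.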